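Antagonist potency at the chemokine receptor: a basic side-chain swap

The source may hold more compounds than are shown below. What is called first, only, known or untested is meant among the compounds shown, and "the series" means these compounds.

Measured compounds:
compound 1 `c1ccc2c(c1)CN[C@@H](CN(CC[C@@H]1CCCNC1)[C@H]1CCCc3cccnc31)C2`: 161 nM
compound 2 `c1cnc2c(c1)CCC[C@@H]2N(CCCN1CCNCC1)Cc1cc2ccccc2cn1`: 17 nM
compound 3 `c1cnc2c(c1)CCC[C@@H]2N(CCCN1CCNCC1)Cc1nc2ccccc2[nH]1`: 45 nM

In a functional assay on CCRF-CEM cells for antagonist activity at C-X-C chemokine receptor type 4 (Homo sapiens), read by calcium flux, with stated times of 25 min and 90 s (a lower number here means a stronger inhibitor, a higher number a weaker inhibitor), compound 1 stands at the highest number of the three, the weakest inhibitor of this set. Within the data shown here, the only single-point step measured, a 2.6-fold higher number from compound 2 to compound 3 (0.42 log units; beyond the scatter), concerns a different part of the molecule and does not bear on the change in hand. Compound 4 `CN1CCN(CCCN(C[C@H]2Cc3ccccc3CN2)[C@H]2CCCc3cccnc32)CC1` differs from compound 1 by (4-methylpiperazin-1-yl)methyl in place of piperidin-3-yl on a saturated chain carbon, two bonds along the chain from an amine nitrogen. Among the measured compounds shown here, no measured pair isolates this exchange; compounds 2 and 3, built on the same core, merely show that lower numbers are reachable. A step toward a lower number is therefore expected for compound 4, but with wide uncertainty: the estimate is 60 nM, between 20 nM and 200 nM, that is a 2.7-fold lower number from compound 1 to compound 4 (0.43 log units; beyond the scatter).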

Compound 4, half-maximal inhibitory concentration: 125 nM
Compound 4: the middle estimate sits 2.1-fold (0.32 log units) below what was measured; the range from low to high includes it.
By their numbers in this assay, from the lowest: compound 2; then compound 3; then compounds 4 and 1 (each within the scatter of the next).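

In this assay, placing (4-methylpiperazin-1-yl)methyl instead of piperidin-3-yl on this saturated chain carbon gives a 1.3-fold lower number from compound 1 to compound 4 (0.11 log units; within the scatter), so the two compounds cannot be told apart. The exchange thus leaves the number unresolved even though the entering group has no hydrogen-bond donor and no defined stereocentre, while the leaving group has one of each. Nothing available explains this result. On these data alone, it remains open whether a morpholin-4-yl group or a primary amine at this place would give a different number. Also open, as far as these compounds go, is whether an unsubstituted piperazin-1-yl group would read differently from its methylated form here.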